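The source may report more compounds than this note shows. Statements on the series, on what has been measured and on what is new or still open speak of the compounds shown alone.

In a functional assay on Huh7.5.1 cells (Homo sapiens) for cytotoxicity, read by MTT assay, with a stated time of 72 h (a higher number here means that more compound is tolerated, a lower number that less compound is tolerated), compound 1 `C=c1[nH]c(=O)/c(=C/c2ccc(C(C)(C)C)cc2)[nH]c1=O` gives > 20000 nM, which is a limit of the assay and not a number. Compound 2 `C=c1[nH]c(=O)/c(=C/c2ccc(C(=O)OC)cc2)[nH]c1=O` gives > 20000 nM, which is also a limit. Compound 2 therefore has no number of its own, and the picture so far is the limit of > 20000 nM in this assay, at which 2 of the 2 values shown sit. Compound 3 `C=c1[nH]c(=O)/c(=C/c2ccc(C(F)(F)F)cc2)[nH]c1=O` is reached from compound 2 through trifluoromethyl in place of methoxycarbonyl on an aromatic carbon, para to a large group. Among the measured compounds shown here, the substituent changes at the same place as in the only measured step that bears on this change, a step that the two limits leave unreadable from compound 1 to compound 2. That step replaced tert-butyl with methoxycarbonyl, and it gives no size to carry forward. What can be said is that neither substituent brought a measurable value below the limit in this assay. No step beyond the usual scatter is therefore expected, and no direction can be given. The expected step is a step that the limit leaves unreadable from compound 2 to compound 3. Compound 3 is estimated at 25000 nM, with an expected range from 12000 nM to 50000 nM, and the assay may well report only a limit again.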

Compound 3, half-maximal cytotoxic concentration: > 20000 nM
Compound 3: a limit, no number; the forecaster's own chance of this, stated with the estimate: 80%; the middle value lies beyond the limit too.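

In this assay compound 3 gives > 20000 nM as a limit of the assay and not a number, so the steps to compound 3 from compound 1 and compound 2 cannot be read. The compounds shown leave open how much of each is tolerated and whether tert-butyl, methoxycarbonyl and trifluoromethyl differ at all, and the picture now stands as follows: the limit of > 20000 nM in this assay, at which 3 of the 3 values shown sit.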